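The source may report more compounds than this note shows. Statements on the series, on what has been measured and on what is new or still open speak of the compounds shown alone.

Compound 1 `CC(C)=CCc1c(O)cc(/C=C/c2ccc(O)cc2O)cc1O`: > 10000 nM, a limit
Compound 2 `CC(C)=CCc1c(O)cc2c(c1/C=C\c1ccc(O)cc1)CCC(C)(C)O2`: 4900 nM
Compound 3 `CC(C)=CCc1c(O)cc(O)c(CC=C(C)C)c1/C=C/c1ccc(O)cc1`: 12800 nM

These results come from an ADME assay on THP-1 cells (Homo sapiens) for cytotoxicity, read by WST assay, with a stated time of 24 h; on this read-out higher numbers stand for weaker inhibition and lower numbers for stronger inhibition. The value of compound 1 is a limit of the assay and not a number. Of the two actual numbers, compound 3 has the higher, 12800 nM, and the gap down to compound 2 at 4900 nM lies beyond the scatter.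

Compound 4 `COc1ccc(/C=C/c2c(CC=C(C)C)c(O)cc(O)c2CC=C(C)C)cc1O` has yet to be measured. It differs from compound 3 by 3-hydroxy-4-methoxyphenyl in place of 4-hydroxyphenyl on a double-bonded chain carbon bound to a double-bonded chain carbon. Within the data shown here, no measured pair shows this change alone, so no step beyond the scatter is expected in this assay. The expected step is a 1.2-fold lower number from compound 3 to compound 4 (0.09 log units; within the scatter), a small estimated shift toward a lower number. For compound 4 the estimated value is 10500 nM, with an expected range of 5000 nM to 22000 nM.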

Compound 4, half-maximal inhibitory concentration: 3900 nM
Estimate against measurement, compound 4: 2.7-fold (0.43 log units) above, and the stated range ends above it.
By their numbers in this assay, from the lowest: compounds 4 and 2 (each within the scatter of the next); then compound 3.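

In this assay, among these compounds, 3-hydroxy-4-methoxyphenyl in place of 4-hydroxyphenyl on a double-bonded chain carbon bound to a double-bonded chain carbon gives a 3.3-fold lower number from compound 3 to compound 4 (0.52 log units; beyond the scatter) and thereby shows, as no earlier pair could, that a change at this place alone moves the read-out toward stronger inhibition. The compounds shown offer no cause for this step. Still open, from the compounds shown here alone, is whether the hydroxy or the methoxy of the new group carries the step, and how an amine or a carboxylic acid at this place would read.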